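The source may report more compounds than this note shows. Statements on the series, on what has been measured and on what is new or still open speak of the compounds shown alone.

Working notes on the series. In an ADME assay on a cell-free system (plasma, Homo sapiens) (on this read-out higher numbers stand for a larger free fraction and lower numbers for a smaller free fraction), compound 1 (`CCCS(=O)(=O)c1cccc(C#Cc2cc(Cl)ccc2OCC(=O)O)c1`) gives 0.008 and compound 2 (`Cc1ccc(S(=O)(=O)N(C)C(C)C)cc1C#Cc1cc(Cl)ccc1OCC(=O)O`) gives 0.002. Compound 2 therefore holds the lower of the two numbers, and the gap to compound 1 lies beyond the scatter. Compound 3 (`Cc1ccc(S(=O)(=O)NC(C)C)cc1C#Cc1cc(Cl)ccc1OCC(=O)O`) has yet to be measured in this assay. It differs from compound 2 in one place: hydrogen in place of methyl on a sulfonamide nitrogen. For the measured compounds named here, no measured pair shows this change on its own, so the expectation rests only on the structural difference and on the starting number of compound 2, 0.002. The expected step is a 1.5-fold higher number from compound 2 to compound 3 (0.18 log units; within the scatter), a small rise in free fraction that probably stays within the scatter. For compound 3 the estimated value is 0.003, with an expected range of 0.0015 to 0.007.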

Compound 3, unbound fraction: 0.004
Estimate against measurement, compound 3: 1.3-fold (0.12 log units) below; measured number inside the range.
By their numbers in this assay, from the lowest: compounds 2, 3 and 1 (each within the scatter of the next, the first and the last beyond it).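

In this assay, for the compounds shown here, this pair gives the first reading of hydrogen in place of methyl on a sulfonamide nitrogen on its own, with a 2.0-fold higher number from compound 2 to compound 3 (0.30 log units; within the scatter). The two compounds therefore cannot be told apart in free fraction, and on this one pair the sulfonamide nitrogen carries either hydrogen or methyl without a step beyond the scatter. Nothing at hand bears on what lies behind this reading.

Going by these compounds, this is a single pair, so it remains open whether the same change would read alike with another group in place of isopropyl on that nitrogen, such as cyclopropyl or a longer chain. Also open, on these data alone, is how ethyl or a longer chain in place of methyl on the same sulfonamide nitrogen would read in this assay.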